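A few compounds are considered here, and "the series" means these few. Any claim that something is new, unique, unknown or untested is made for them only; others in the source may bear on it.

Maximal responses measured in an assay on HEK293 cells for positive allosteric modulation of metabotropic glutamate receptor 2 (Rattus norvegicus), read by thallium flux, with a stated time of 2.5 min; on this read-out higher numbers stand for larger maximal responses and lower numbers for smaller maximal responses:

compound 1 `Cc1c(OCCCCOc2ccc(C(=O)O)cc2Cl)ccc(C(=O)CC2CCCC2)c1O`: 82.2%
compound 2 `Cc1c(OCCCCOc2ccc(C(=O)O)cc2Cl)ccc(C(=O)CC(C)C)c1O`: 99.5%
compound 3 `Cc1c(OCCCCOc2ccccc2C(=O)O)ccc(C(=O)CC(C)C)c1C`: 76.2%

Compound 1 stands second highest of the three numbers in this assay. Its nearest neighbour is compound 3, whose value lies within the scatter of that of compound 1, so the two cannot be told apart on this read-out. For the measured compounds named here, the only step measured in one place, a number 17.3 percentage points higher from compound 1 to compound 2 (beyond the scatter), concerns the saturated chain carbon bound to the carbonyl carbon and leaves the rest of the molecule untouched.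

Compound 4 `Cc1c(OCCCCOc2ccc(F)c(C(=O)O)c2)ccc(C(=O)CC2CCCC2)c1O` is not yet measured. It differs from compound 1 in one place: 3-carboxy-4-fluorophenyl in place of 4-carboxy-2-chlorophenyl on an oxygen on a saturated carbon. Going by the values given here, no measured step changes this part of the molecule, so the step in this assay from compound 1 to compound 4 has no direct precedent. Compound 3 carries a different acid-bearing ring and a different core substituent, and its value is within the scatter of compound 1, which gives no sign that this region moves the maximal response far. Among the compounds with values here, with no bearing step, no change beyond the scatter is expected; the estimate is a number 2.2 percentage points lower from compound 1 to compound 4 (within the scatter). Compound 4 is therefore expected to give about 80% in this assay, with a range from 62% to 98%.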

Compound 4, largest response reached (reported as percent of maximum), in percent of the reference or control that the assay uses: 81%
The estimate for compound 4 lay 1 percentage points below the measured number; low and high end bracket the measured number.
By their numbers in this assay, from the lowest: compounds 3, 4 and 1 (each within the scatter of the next); then compound 2.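

For the compounds shown here, the change from 4-carboxy-2-chlorophenyl to 3-carboxy-4-fluorophenyl on an oxygen on a saturated carbon gives the first direct reading at this position in this assay: a number 1.2 percentage points lower from compound 1 to compound 4 (within the scatter). With the cyclopentyl group held constant, the two rings cannot be told apart on this read-out, even though the carboxy group and the halogen are placed differently and chlorine gives way to fluorine. Going by these compounds alone, the only single-place step beyond the scatter therefore remains the one on the saturated chain carbon bound to a carbonyl carbon, a number 17.3 percentage points higher from compound 1 to compound 2 (beyond the scatter), and nothing at hand explains why the two rings read alike.

Going by these compounds, it remains open whether 3-carboxy-4-fluorophenyl would also read alike with the isopropyl group of compound 2, since this single pair shows the ring change only with cyclopentyl. Also open, on these data alone, is how the maximal response would respond at this position to a tetrazole in place of the carboxylic acid, or to a nitrile in place of the halogen.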